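This account rests on a few compounds, and the source may have more. Where it says the series, first, only, none or still open, it means among the compounds named here.

Working notes on the series. Compound 1 `N#CC1=C(N)Oc2c(c3nc4ccccc4nc3c3ccccc23)C12C(=O)N(Cc1cnnn1-c1ccc(S(N)(=O)=O)cc1)c1ccccc12` carries 4-sulfamoylphenyl on the aromatic nitrogen; in an ADME assay on L02 cells (Homo sapiens) for antiproliferative activity, read by MTT assay, with a stated time of 48 h (on this read-out lower numbers stand for stronger inhibition and higher numbers for weaker inhibition), compound 1 gives > 50000 nM, which is a limit of the assay and not a number. Compound 2 `Cc1ccc(C)c(-n2nncc2CN2C(=O)C3(C(C#N)=C(N)Oc4c3c3nc5ccccc5nc3c3ccccc43)c3ccccc32)c1` carries 2,5-dimethylphenyl in that position; in this assay compound 2 gives > 50000 nM, again a limit. The step that the two limits leave unreadable from compound 1 to compound 2 is therefore not readable. Compound 3 `Cc1cccc(-n2nncc2CN2C(=O)C3(C(C#N)=C(N)Oc4c(N)cc5nc6ccccc6nc5c43)c3ccccc32)c1` carries 3-methylphenyl on the aromatic nitrogen; in this assay compound 3 gives > 50000 nM, a limit. Compound 3 thus stands where the other two stand, namely at the limit of > 50000 nM in this assay, at which 3 of the 3 values shown sit.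

The change to compound 4 `N#CC1=C(N)Oc2c(N)cc3nc4ccccc4nc3c2C12C(=O)N(Cc1cnnn1-c1ccc(F)cc1)c1ccccc12` is 4-fluorophenyl in place of 3-methylphenyl on an aromatic nitrogen. Within the data shown here, no measured step bears on this change directly; the single measured step concerns a different pair of aryl groups and is itself unreadable because both its ends sit at the limit of > 50000 nM in this assay, at which 3 of the 3 values shown sit. With every value in this assay at the limit, compound 4 is expected to remain there as well, and the expected step that the limit leaves unreadable from compound 3 to compound 4 is not expected to exceed the scatter. Compound 4 is estimated at 60000 nM in this assay, with a range from 30000 nM to 150000 nM, most likely again as a limit.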

Compound 4, half-maximal inhibitory concentration: > 50000 nM
Compound 4 was reported as a limit; the forecaster's own chance of this, stated with the estimate: 85%; the middle value does not contradict the limit.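

In this assay compound 4 gives > 50000 nM, again a limit and not a number. No step from compound 3 to compound 4 can therefore be read, and the series stays where it stood: the limit of > 50000 nM in this assay, at which 4 of the 4 values shown sit.

The compounds shown leave open how far each true value lies from this limit and whether any aryl group or change to the shared core would give a measurable value.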